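A few compounds are considered here, and "the series" means these few. Any claim that something is new, unique, unknown or untested is made for them only; others in the source may bear on it.

Compound 1 `Cc1ccc(COc2ccc(C(=O)NC(=O)Nc3ccc(C)c(-c4nc5ccccc5[nH]4)c3)cc2)cc1` belongs to a set of three compounds that share one core and differ only in the group carried on a saturated chain carbon bound to an oxygen on an aromatic ring. In a functional assay on MNK45 cells (Homo sapiens) for inhibition, read by MTT assay, with a stated time of 48 h (on this read-out higher numbers stand for weaker inhibition and lower numbers for stronger inhibition), compound 1 gives 6360 nM, the second highest of the three numbers. Compound 2 `Cc1ccc(NC(=O)NC(=O)c2ccc(OCc3cccc(F)c3)cc2)cc1-c1nc2ccccc2[nH]1` gives 53000 nM, and compound 3 `Cc1ccc(NC(=O)NC(=O)c2ccc(OCc3ccc(Cl)cc3Cl)cc2)cc1-c1nc2ccccc2[nH]1` gives 2550 nM; the steps between them are an 8.3-fold higher number from compound 1 to compound 2 (0.92 log units; beyond the scatter), a 2.5-fold lower number from compound 1 to compound 3 (0.40 log units; beyond the scatter) and a 21-fold lower number from compound 2 to compound 3 (1.32 log units; beyond the scatter). Compound 4 `Cc1ccc(COc2ccc(C(=O)NC(=O)Nc3ccc(Cl)c(-c4nc5ccccc5[nH]4)c3)cc2)cc1` differs from compound 1 at another place: chloro in place of methyl on an aromatic carbon. Within the data shown here, none of the measured steps touches that aromatic carbon, so they give no direct guide, and a change within the scatter is expected. Compound 4 is therefore expected to give about 6000 nM, between 2000 nM and 18000 nM, which means a 1.1-fold lower number from compound 1 to compound 4 (0.03 log units; within the scatter) is expected.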

Compound 4, half-maximal inhibitory concentration: 3190 nM
Beside the measured number, compound 4's estimate is 1.9-fold (0.27 log units) above it, and the stated range covers the measured number.
By their numbers in this assay, from the lowest: compounds 3, 4 and 1 (each within the scatter of the next, the first and the last beyond it); then compound 2.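

On the aromatic carbon ortho to a 1H-benzimidazol-2-yl group, chloro in place of methyl gives a 2.0-fold lower number from compound 1 to compound 4 (0.30 log units; within the scatter) in this assay, so the two groups cannot be told apart at this carbon. The earlier steps shown here, all made at the other end of the molecule, gave differences beyond the scatter, whereas this first look at the new position gives none. Nothing measured here offers an explanation for this result. As far as these compounds go, what an amine or a carboxylic acid on this carbon would do remains open. So does whether chloro here would behave the same alongside the 2,4-dichlorophenyl group of compound 3.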